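Methyl on the Pendant Phenyl of Thiosemicarbazide Analogues

The compounds below may be only part of what the source reports. "The series", "measured", "known", "first", "only" and "open" are said of these compounds alone.

Measured compounds:
compound 1 `COc1ccc(C(=O)NNC(=S)Nc2csc(-c3ccccc3)c2)cc1` gives 36000 nM
compound 2 `COc1ccc(C(=O)NNC(=S)Nc2csc(-c3ccc(C)cc3)c2)cc1` gives 11000 nM
compound 3 `O=C(NNC(=S)Nc1csc(-c2ccccc2)c1)c1ccc(O)cc1` gives 75000 nM

In a functional assay on A549 cells (Homo sapiens) for inhibition, read by colorimetric assay and MTT assay, with a stated time of 72 h (on this read-out higher numbers stand for weaker inhibition and lower numbers for stronger inhibition), compound 1 gives 36000 nM, compound 2 gives 11000 nM and compound 3 gives 75000 nM. The change from compound 1 to compound 2 is methyl in place of hydrogen on an aromatic carbon, and it brings a 3.3-fold lower number from compound 1 to compound 2 (0.51 log units; beyond the scatter). Compound 3 differs from compound 1 by hydrogen in place of methyl on an oxygen on an aromatic ring, giving a 2.1-fold higher number from compound 1 to compound 3 (0.32 log units; beyond the scatter), so compound 3 stands highest of the three.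

Compound 4 `Cc1ccc(-c2cc(NC(=S)NNC(=O)c3ccc(O)cc3)cs2)cc1` has not been measured. It differs from compound 3 by methyl in place of hydrogen on an aromatic carbon, the same change as from compound 1 to compound 2, on the same place. Within the data shown here, because compound 1 to compound 2 showed a 3.3-fold lower number from compound 1 to compound 2 (0.51 log units; beyond the scatter), a step of similar size is expected from compound 3 to compound 4, about a 3.3-fold lower number from compound 3 to compound 4 (0.51 log units; beyond the scatter), though only one earlier example supports this. Compound 4 is therefore estimated at 23000 nM, within 9000 nM to 60000 nM.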

Compound 4, half-maximal inhibitory concentration: 44000 nM
Compound 4: middle estimate off by 1.9-fold (0.28 log units), on the low side, within the range that was stated.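

In this assay, the methyl step on the core of compound 3 gives a 1.7-fold lower number from compound 3 to compound 4 (0.23 log units; within the scatter), and this does not differ measurably from the earlier step on the core of compound 1: the same change on two cores in this assay, a 3.3-fold lower number (0.51 log units; beyond the scatter) from compound 1 to compound 2 and a 1.7-fold lower number (0.23 log units; within the scatter) from compound 3 to compound 4, 1.9-fold (0.28 log units) apart, within the scatter of two such steps. Hydrogen in place of methyl on the oxygen gives a 4.0-fold higher number from compound 2 to compound 4 (0.60 log units; beyond the scatter), and this step also agrees with its earlier counterpart: the same change on two cores in this assay, a 2.1-fold higher number (0.32 log units; beyond the scatter) from compound 1 to compound 3 and a 4.0-fold higher number (0.60 log units; beyond the scatter) from compound 2 to compound 4, 1.9-fold (0.28 log units) apart, within the scatter of two such steps. Both changes therefore carry across these two cores, but each comparison rests on a single pair of steps, and the methyl step on the core of compound 3 lies within the scatter, so a reliable gain from methyl on every core is not shown.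

The compounds shown leave open whether ethyl or chlorine in place of that methyl would shift the number in the same way. They also leave open how an amine in place of the oxygen substituent would behave on either core.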